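Swapping fluoro for chloro on the aromatic amide

The source may hold more compounds than are shown below. What is called first, only, known or untested is meant among the compounds shown, and "the series" means these compounds.

The values below come from a functional assay on MDA-MB-231 cells (Homo sapiens) for antiproliferative activity, read by MTT assay, with a stated time of 72 h (a lower number here means a stronger inhibitor, a higher number a weaker inhibitor), and read as follows:
Compound 1 `CCNC(=O)CCc1cccc2c1B(O)OC2` gives > 100000 nM as a limit of the assay
Compound 2 `O=C(CCc1cccc2c1B(O)OC2)Nc1nccs1` gives > 100000 nM as a limit of the assay
Compound 3 `O=C(CCc1cccc2c1B(O)OC2)Nc1ccc(F)cc1` gives 440 nM as a measured number

Compound 3 is the only one of the three with a number. The other two are bounded by the limit of > 100000 nM in this assay, at which 2 of the 3 values shown sit, and nothing finer can be read from them.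

Compound 4 `O=C(CCc1cccc2c1B(O)OC2)Nc1ccc(Cl)cc1` differs from compound 3 by chloro in place of fluoro on an aromatic carbon and the change sits on an aromatic carbon of a six-membered aromatic ring of carbon only, para to a large group.

Among the measured compounds shown here, two measured steps bear on this only indirectly. They are an at least 220-fold lower number from compound 1 to compound 3 (2.35 log units; beyond the scatter) and an at least 220-fold lower number from compound 2 to compound 3 (2.35 log units; beyond the scatter) and both are large and beyond the scatter. Each of them changes the whole group on the amide nitrogen, and neither changes the halogen, so no measurement compares fluoro with chloro directly.

Compound 4 keeps the aromatic ring on that nitrogen, so a step of that size is not expected. The expectation is anchored on compound 3 at 440 nM with no change beyond the scatter expected in this assay for this swap. The expected step is a 1.1-fold lower number from compound 3 to compound 4 (0.04 log units; within the scatter) on this reasoning. For compound 4 the estimated value is 400 nM with an expected range from 120 nM to 1800 nM as the likely span.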

Compound 4, half-maximal inhibitory concentration: 3600 nM
Estimate against measurement, compound 4: 9.0-fold (0.95 log units) below, and the stated range ends below it.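

In this assay, among the compounds shown here, the halogen turns out not to be interchangeable at this place, an aromatic carbon para to a large group: the direct comparison shows an 8.2-fold higher number from compound 3 to compound 4 (0.91 log units; beyond the scatter), so a swap of one heavy atom for one heavy atom is enough to shift the read-out on its own, which the earlier steps, each replacing the whole group on the amide nitrogen, could not show. Even so, the 4-chlorophenyl group keeps a large separation from the two other amide groups, with an at least 27-fold lower number from compound 2 to compound 4 (1.44 log units; beyond the scatter) and an at least 27-fold lower number from compound 1 to compound 4 (1.44 log units; beyond the scatter), so the change of halogen gives up only part of what the aromatic ring on that nitrogen brings. Those two steps give minimum sizes and not exact ones, because compound 1 and compound 2 each sit at a limit: the limit of > 100000 nM in this assay, at which 2 of the 4 values shown sit.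

Going by these compounds, two halogens make no series, so it remains open whether hydrogen, bromo, methyl or methoxy on the same carbon would read closer to fluoro or to chloro. Nothing shown here accounts for the step between the two halogens, and whether it would hold on another amide group also stays open.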